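A few compounds are considered here, and "the series" means these few. Any claim that something is new, unique, unknown or untested is made for them only; others in the source may bear on it.

Compound 1, `CCOC(=O)c1nn(-c2ccc(Cl)cc2)c(-c2ccc(OC)cc2OC)c1C`: 0%
Compound 2, `COc1ccc(C2=NN(C(=O)NS(=O)(=O)c3ccc(C)cc3)CC2c2ccccc2)c(OC)c1`: 4.9%
Compound 3, `COc1ccc(C2=NN(C(=S)NC(=O)c3ccc(Cl)cc3)CC2C)c(OC)c1`: 0%

These three compounds were tested in a functional assay on the whole organism (strain albino) for inhibition, with Rattus norvegicus as the target, read by paw edema, with stated times of 30 min and 1 h, at a dose of 25 mg/kg by the intraperitoneal route; on this read-out lower numbers stand for less inhibition and higher numbers for more inhibition at the one dose given (going by the name of the read-out). Compound 1 gives 0%, compound 2 gives 4.9% and compound 3 gives 0%. Compound 3 thus matches compound 1 at the digits given, and the number for compound 2 is higher by an amount that lies inside the usual scatter of such measurements, so none of the three is set apart from the others: all sit at the floor of the read-out, with essentially no reduction of the paw swelling at the dose used.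

Compound 4, `COc1ccc(C2=NN(C(=S)NC(=O)c3ccc(Cl)cc3)CC2c2ccccc2)c(OC)c1`, has not yet been measured. It differs from compound 3 in one place: phenyl in place of methyl on a saturated ring carbon. The shared core of compound 3 and compound 4 is otherwise unchanged, as is the thiourea-linked chlorobenzoyl side.

For the measured compounds named here, no pair of measured compounds differs in exactly this way, so there is no measured step to lean on. Given that compound 3 shows 0% and that the three measured compounds lie within the scatter of one another, the expected step from compound 3 to compound 4 in this assay is a number 5 percentage points higher from compound 3 to compound 4 (within the scatter), that is, no change beyond the scatter in either direction. Compound 4 is therefore expected to give about 5%, within a range from 0% to 20%.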

Compound 4, a percentage reported as inhibition, in the whole organism at one dose (the size of the read-out at that dose, not a potency): 0%
Beside the measured number, compound 4's estimate is 5 percentage points above it, and the stated range covers the measured number.
By their numbers in this assay, from the lowest: compounds 1, 3, 4 and 2 (each within the scatter of the next).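

For the compounds shown here, the swap of methyl for phenyl on the saturated ring carbon is the first one-place change that can be read in this set, and in this assay it shows no change at the digits printed from compound 3 to compound 4 (within the scatter) at the one dose given. Adding a whole aromatic ring at this position therefore does not lift the number off the bottom of the scale. A read-out already at its floor cannot show any further loss, however, so this step reveals only the absence of a gain with phenyl and does not show that the two groups behave alike; nothing available explains the lack of response at this position.

On these data alone, whether a different group on this saturated ring carbon, such as an amine or a carboxylic acid, would move the number in this assay remains open. Equally open, as far as these compounds go, is whether changing the thiourea-linked chlorobenzoyl side, for instance by replacing the chlorine with a methoxy group, would give a response that makes differences at this position visible.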